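Exchanging 3-methylpyridin-4-yl for 4-methylthiophen-3-yl

This account rests on a few compounds, and the source may have more. Where it says the series, first, only, none or still open, it means among the compounds named here.

In an ADME assay on the whole organism for pharmacokinetics, with Mus musculus as the target, at a dose of 10 mg/kg by the oral route (a lower number here means less compound in the circulation, a higher number more compound in the circulation at the dose given), compound 2 `CC/C(=C(/c1ccc(/C=C/C(=O)O)cc1)c1ccc2[nH]ncc2c1)c1ccncc1C` is the lower of the two measured compounds at 81 ng.h/mL, and compound 1 `CC/C(=C(/c1ccc(/C=C/C(=O)O)cc1)c1ccc2[nH]ncc2c1)c1ccccc1C` gives 7200 ng.h/mL. Compound 3 `CC/C(=C(/c1ccc(/C=C/C(=O)O)cc1)c1ccc2[nH]ncc2c1)c1cscc1C` changes one group: 4-methylthiophen-3-yl in place of 3-methylpyridin-4-yl on a double-bonded chain carbon bound to a double-bonded chain carbon and a saturated chain carbon. Going by the values given here, the only measured step bearing on this is an 89-fold lower number from compound 1 to compound 2 (1.95 log units; beyond the scatter), where 3-methylpyridin-4-yl replaced 2-methylphenyl at the same place. Like the 2-methylphenyl of compound 1 at 7200 ng.h/mL, 4-methylthiophen-3-yl contains no nitrogen, so a large rise in this assay is expected, recovering most of that step. The expected step is a 31-fold higher number from compound 2 to compound 3 (1.49 log units; beyond the scatter). For compound 3 the estimate is 2500 ng.h/mL, with an expected range of 400 ng.h/mL to 9000 ng.h/mL.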

Compound 3, area under the concentration-time curve: 3800 ng.h/mL
For compound 3 the middle estimate is 1.5-fold (0.18 log units) below the measured one; the measured number falls inside the stated range.
By their numbers in this assay, from the lowest: compound 2; then compounds 3 and 1 (each within the scatter of the next).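

In this assay the step is a 47-fold higher number from compound 2 to compound 3 (1.67 log units; beyond the scatter), so the low number of compound 2 does not extend to every ring with a hetero atom at this position. Against 2-methylphenyl the step is a 1.9-fold lower number from compound 1 to compound 3 (0.28 log units; within the scatter), so in this assay a five-membered aromatic ring with sulfur is not separated from the six-membered carbon ring of compound 1. No measurement at hand accounts for these steps.

The compounds shown hold only one nitrogen-bearing ring at this position, so whether the ring nitrogen itself goes with the low number stays open. Also open, going by these compounds, is how an amine or a longer chain in place of the methyl of 4-methylthiophen-3-yl would read in this assay.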